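Series notes: the fused core and the amino-for-methyl step

A few compounds are considered here, and "the series" means these few. Any claim that something is new, unique, unknown or untested is made for them only; others in the source may bear on it.

Three compounds have numbers in a functional assay on the whole organism for inhibition, with Rattus norvegicus as the target, with stated times of 1 h and 3.5 h, at a dose of 100 mg/kg by the oral route; on this read-out lower numbers stand for less inhibition and higher numbers for more inhibition at the one dose given (going by the name of the read-out). Compound 1 `Cc1cnc(N)nc1-c1ccccc1` gives 34% in this assay. Compound 2 `CCOC(=O)Nc1nccc(-c2ccncc2)n1` gives 31% in this assay. Compound 3 `Cc1ncc2c(n1)CCN(C)C2` gives 45% in this assay, the highest of the three: its gap to compound 1 and its gap to compound 2 both lie beyond the usual scatter. No pair among these three differs in a single place, so no step between measured compounds can be taken as a guide.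

The next compound, compound 4 `CN1CCc2nc(N)ncc2C1`, differs from compound 3 in one place: amino in place of methyl on an aromatic carbon, on an aromatic carbon of a six-membered aromatic ring with two nitrogen atoms, between two ring nitrogen atoms, within the fused system of two rings. Within the data shown here, compound 1 carries an amino group on a six-membered ring with two nitrogen atoms and gives 34% in this assay, but its core is not that of compound 3, so this is no direct precedent.

The step from compound 3 to compound 4 in this assay is expected to be small, a number 5 percentage points lower from compound 3 to compound 4 (within the scatter), within the usual scatter. Compound 4 is estimated at 40% in this assay, expected between 25% and 55%.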

Compound 4, a percentage reported as inhibition, in the whole organism at one dose (the size of the read-out at that dose, not a potency): < 5%
Compound 4: only a limit was reported (the forecaster's own chance of this, stated with the estimate: 0%); middle value at least 35 percentage points from the limit.
By their numbers in this assay, from the lowest: compounds 2 and 1 (each within the scatter of the next); then compound 3. At a limit, below all of these: compound 4.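

Among these compounds, the position between two ring nitrogen atoms on the fused system proves sensitive to the group it carries: in this assay, amino in place of methyl gives a number at least 40 percentage points lower from compound 3 to compound 4 (beyond the scatter), the first step that can be read. For compound 4, the value < 5% is a limit of the assay and not a number: the limit of < 5% in this assay, at which 1 of the 4 values shown sits. The exchange of a single heavy atom, with a hydrogen-bond donor and a hydrogen-bond acceptor entering where methyl carried neither, thus goes with a large loss of inhibition at the one dose given.

The compounds shown do not tell whether this loss follows the arrival of amino or the departure of methyl. Ethyl, methoxy or dimethylamino at this same place on the core of compound 3 would bear on that question.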